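The source may report more compounds than this note shows. Statements on the series, on what has been measured and on what is new or still open speak of the compounds shown alone.

Measured so far:
- compound 1, `Oc1ccc(CCCCC(O)CCc2ccc(O)cc2)cc1`: 43%
- compound 2, `COc1cc(/C=C/C(=O)CCCCc2ccc(O)c(OC)c2)ccc1O`: 66%

In an ADME assay on HT-22 cells (Mus musculus) for cytotoxicity, read by MTT assay, with a stated time of 24 h, tested at 10 uM (on this read-out lower numbers stand for a stronger effect and higher numbers for a weaker effect at the one concentration tested), compound 1 gives the lower of the two numbers, and compound 2 stands a good way higher, beyond the usual scatter. The two compounds differ in several places at once, so their values show only where each stands, not what any single change does.

Compound 3, `COc1cc(CCCCC(O)CCc2ccc(O)cc2)ccc1O`, has not yet been measured. It differs from compound 1 in one place: methoxy in place of hydrogen on an aromatic carbon. Going by the values given here, no pair of measured compounds differs in only this way, so nothing measured shows directly how this change acts. Compound 2 also carries methoxy groups and gives the higher number, but too much else differs for that to count. For compound 3 a small upward step, a number 7 percentage points higher from compound 1 to compound 3 (within the scatter), is expected, one that may not exceed the scatter. Compound 3 is estimated at 50%, with a range from 30% to 70%.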

Compound 3, a percentage reported as activity, at one concentration (the size of the read-out at that concentration, not a potency): 74%
For compound 3 the middle estimate is 24 percentage points below the measured one, outside the stated range (above it).
By their numbers in this assay, from the lowest: compound 1; then compounds 2 and 3 (each within the scatter of the next).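

In this assay, methoxy in place of hydrogen on an aromatic carbon, ortho to a hydroxy group, gives a number 31 percentage points higher from compound 1 to compound 3 (beyond the scatter). Going by these compounds alone, this is the first pair that isolates this change, and it shows that this single substitution on the core of compound 1 is enough to shift the read-out clearly. On this read-out the higher number means a weaker effect at the one concentration tested, so here the methoxy group goes with a weaker effect, and nothing available explains the shift.

The compounds shown leave open whether a different group at this place, such as an ethoxy group, a fluorine atom or an amine, would shift the number as far. They also leave open whether the same step would appear without the hydroxy group on that ring.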